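The source may report more compounds than this note shows. Statements on the series, on what has been measured and on what is new or still open speak of the compounds shown alone.

Compound 1 `O=C(CCc1nc2ccccc2c(=O)[nH]1)N/N=C/c1ccc([N+](=O)[O-])cc1` gives 220000000 nM

Compound 2 `O=C(CCc1nc2ccccc2c(=O)[nH]1)N/N=C/c1ccc(O)cc1` gives 105000000 nM

For the measured compounds named here, these numbers come from a physicochemical assay, read by spectrophotometry, with a stated time of 6 min (a higher number here means a weaker inhibitor, a lower number a stronger inhibitor), and compound 2 has the lower of the two, with compound 1 as its only neighbour. The next molecule is compound 3 `O=C(CCc1nc2ccccc2c(=O)[nH]1)N/N=C/c1ccc(Cl)cc1` and it keeps the shared core while one group changes (chloro in place of hydroxy on an aromatic carbon). In words, this is chloro in place of hydroxy on an aromatic carbon, para to a large group. Going by the values given here, only one measured step bears on this change, a modest one that also involves hydroxy on an aromatic carbon (a 2.1-fold lower number from compound 1 to compound 2 (0.32 log units; beyond the scatter)). With that single step as a guide, losing the hydroxy is expected to raise the number slightly, though probably not beyond the scatter. The expected change is a 1.5-fold higher number from compound 2 to compound 3 (0.18 log units; within the scatter) in this assay and it remains only an estimate. For compound 3 the estimated value is 160000000 nM with an expected range from 80000000 nM to 320000000 nM in this test.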

Compound 3, half-maximal inhibitory concentration: 185000000 nM
Compound 3: the middle estimate sits 1.2-fold (0.06 log units) below what was measured, within the range that was stated.
By their numbers in this assay, from the lowest: compounds 2, 3 and 1 (each within the scatter of the next, the first and the last beyond it).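

Within this assay the swap of hydroxy for chloro on this aromatic carbon takes away a hydrogen-bond donor and a hydrogen-bond acceptor, yet the outcome is a 1.8-fold higher number from compound 2 to compound 3 (0.25 log units; within the scatter) and no real shift can be claimed. Chloro in place of nitro likewise gives a 1.2-fold lower number from compound 1 to compound 3 (0.08 log units; within the scatter) even though the other two compounds stand apart by more than the scatter, so compound 3 cannot be separated from either of them. Nothing measured here explains how these groups read as they do.

An amine, a carboxylic acid or a methoxy group on this same carbon would test whether the number can move further than these three groups have moved it. Also open, as far as these compounds go, is whether a change elsewhere, such as a longer chain, counts for more than this one.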